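The source may hold more compounds than are shown below. What is called first, only, known or untested is meant among the compounds shown, and "the series" means these compounds.

Compound 3 `CC(C(=O)NCc1ccc(C(F)(F)F)nc1N1CCCCC1C)c1ccc(NS(C)(=O)=O)c(F)c1` gives the lowest number of the three in a functional assay on CHO-K1 cells for antagonist activity at transient receptor potential cation channel subfamily V member 1 (Homo sapiens), read by FLIPR (a higher number here means a weaker inhibitor, a lower number a stronger inhibitor), at 2.9 nM. Compound 1 `CCCCNc1nc(C(F)(F)F)ccc1CNC(=O)C(C)c1ccc(NS(C)(=O)=O)c(F)c1` gives 9.1 nM in this assay, and compound 2 `CC1CCC(Nc2nc(C(F)(F)F)ccc2CNC(=O)C(C)c2ccc(NS(C)(=O)=O)c(F)c2)CC1` gives 27.2 nM. The steps of a 3.1-fold lower number from compound 1 to compound 3 (0.50 log units; beyond the scatter) and a 9.4-fold lower number from compound 2 to compound 3 (0.97 log units; beyond the scatter) both replace an amino substituent with the 2-methylpiperidin-1-yl of compound 3. Compound 4 `CC(C(=O)NCc1ccc(C(F)(F)F)nc1N1CCN(C)CC1)c1ccc(NS(C)(=O)=O)c(F)c1` differs from compound 3 as follows: 4-methylpiperazin-1-yl in place of 2-methylpiperidin-1-yl on an aromatic carbon. Going by the values given here, no measured step exchanges one ring of this kind for another, so those two steps offer only a loose guide. The step to compound 4 is expected to be small, with a mild drift toward a higher number, as a 3.4-fold higher number from compound 3 to compound 4 (0.54 log units; beyond the scatter). The estimate for compound 4 is 10 nM, within the range 3 nM to 40 nM.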

Compound 4, inhibition constant: 146 nM
Beside the measured number, compound 4's estimate is 15-fold (1.16 log units) below it, outside the stated range (above it).
By their numbers in this assay, from the lowest: compound 3; then compound 1; then compound 2; then compound 4.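

At this position, next to the ring nitrogen, the choice between two six-membered non-aromatic rings matters greatly: a 50-fold higher number from compound 3 to compound 4 (1.70 log units; beyond the scatter) is the largest step yet. Compound 4 also trails both amino-substituted compounds, with a 16-fold higher number from compound 1 to compound 4 (1.21 log units; beyond the scatter) and a 5.4-fold higher number from compound 2 to compound 4 (0.73 log units; beyond the scatter), so a ring here brings no gain by itself, with compound 3 alone showing one. No available evidence bears on the reason for this loss. Still open, going by these compounds, is whether a morpholin-4-yl or an unsubstituted piperidin-1-yl would track compound 3 or compound 4, and whether the second ring nitrogen or its methyl group drives the step.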